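A few compounds are considered here, and "the series" means these few. Any claim that something is new, unique, unknown or untested is made for them only; others in the source may bear on it.

Compound 2 `COc1cc(-c2nn(-c3cccc(NC(=O)Nc4ccc(Cl)c(Cl)c4)c3)cc2-c2ccncc2)ccc1Cl` bears a (3,4-dichlorophenyl)amino group on a carbonyl carbon. In a functional assay on 786-0 cells (Homo sapiens) for inhibition, read by sulforhodamine B assay, with a stated time of 48 h (a higher number here means that more compound is tolerated, a lower number that less compound is tolerated), compound 2 reaches only a limit, > 50000 nM. Compound 3 `O=C(Nc1cccc(-n2cc(-c3ccncc3)c(-c3ccc(Cl)c(O)c3)n2)c1)Nc1ccc(Cl)c(Cl)c1` has hydrogen in place of methyl on an oxygen on an aromatic ring; in this assay compound 3 likewise gives a limit, > 32500 nM. The step that the two limits leave unreadable from compound 2 to compound 3 cannot be read because both ends rest on the limit of > 50000 nM in this assay, at which 1 of the 3 values shown sits, and (the limit of > 32500 nM in this assay, at which 1 of the 3 values shown sits). Compound 1 `COc1cc(-c2nn(-c3cccc(NC(=O)Nc4cc(C(F)(F)F)cc(C(F)(F)F)c4)c3)cc2-c2ccncc2)ccc1Cl`, carrying two trifluoromethyl groups, gives a number in this assay, 4310 nM. Compound 4 `COc1cc(-c2nn(-c3cccc(NC(=O)c4ccc(Cl)c(C(F)(F)F)c4)c3)cc2-c2ccncc2)ccc1Cl` differs from compound 2 by 4-chloro-3-(trifluoromethyl)phenyl in place of (3,4-dichlorophenyl)amino on a carbonyl carbon. Among the measured compounds shown here, no measured step covers this exchange, so the step from compound 2 to compound 4 is expected to be roughly an at least 2.5-fold lower number from compound 2 to compound 4 (0.39 log units; beyond the scatter). Compound 4 is therefore estimated at 20000 nM, between 6000 nM and 60000 nM.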

Compound 4, concentration lethal to 50% of the cells: > 32500 nM
Compound 4 ended at the assay's limit; the forecaster's own chance of this, stated with the estimate: 40%; middle value at least 1.6-fold (0.21 log units) away from the limit.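

In this assay compound 4 gives > 32500 nM, which is a limit. Compound 2 also rests on a limit, so the step between compound 2 and compound 4 cannot be read. Going by these compounds, whether 4-chloro-3-(trifluoromethyl)phenyl or (3,4-dichlorophenyl)amino on that carbonyl carbon gives the lower number stays open.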